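The source may report more compounds than this note shows. Statements on the series, on what has been measured and on what is new or still open speak of the compounds shown alone.

Compound 1 `CC(=O)Nc1cccc(NC(=O)COc2ccc3c(=O)ccoc3c2)c1` gives 136 nM in an assay on isolated protein for inhibition of Rho-associated protein kinase 2 (Homo sapiens), read by scintillation counting, radiometric assay and 33P incorporation, with a stated time of 40 min, in the presence of a further agent that is not named here; a higher number here means a weaker inhibitor, a lower number a stronger inhibitor. Among the compounds with values here, compound 2 `O=C(COc1ccc2c(=O)ccoc2c1)Nc1cccc(NC(=O)c2cccc([N+](=O)[O-])c2)c1` gives 41 nM, the lowest of the two numbers so far, and the step of a 3.3-fold lower number from compound 1 to compound 2 (0.52 log units; beyond the scatter) stands beyond the scatter. Compound 3 `O=C(COc1ccc2c(=O)ccoc2c1)Nc1cccc(NC(=O)c2cnc(C(F)(F)F)s2)c1` differs from compound 2 by 2-(trifluoromethyl)-1,3-thiazol-5-yl in place of 3-nitrophenyl on a carbonyl carbon. Within the data shown here, only one measured step bears on this position, the aryl-for-methyl change a 3.3-fold lower number from compound 1 to compound 2 (0.52 log units; beyond the scatter), and no aryl-for-aryl exchange has been measured, so compound 3 is expected to stay near compound 2, with a step of a 1.2-fold higher number from compound 2 to compound 3 (0.09 log units; within the scatter) not expected to exceed the scatter. The estimate for compound 3 is 50 nM, within 20 nM to 130 nM.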

Compound 3, half-maximal inhibitory concentration: 10 nM
Compound 3: the middle estimate sits 5.0-fold (0.70 log units) above what was measured, outside the stated range (below it).
By their numbers in this assay, from the lowest: compound 3; then compound 2; then compound 1.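

In the working series, the group on the carbonyl carbon still matters once it is aromatic: in this assay, 2-(trifluoromethyl)-1,3-thiazol-5-yl in place of 3-nitrophenyl gives a further change (a 4.1-fold lower number from compound 2 to compound 3 (0.61 log units; beyond the scatter)). Measured against methyl, the same group gives a larger overall change (a 14-fold lower number from compound 1 to compound 3 (1.13 log units; beyond the scatter)). Nothing available accounts for this gain. From the compounds shown here alone, the five-membered ring and the trifluoromethyl group enter together, so their shares stay open. A thiazol-5-yl carrying a methyl group or an amine instead of trifluoromethyl would separate them.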